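Trading the ester for a methyl ether

The source may hold more compounds than are shown below. What is called first, only, known or untested is meant among the compounds shown, and "the series" means these compounds.

Of the compounds shown here, three built on one shared core have been measured in a functional assay on HeLa cells (Homo sapiens) for cytotoxicity, read by neutral red uptake, with a stated time of 3 days; a lower number here means a stronger inhibitor, a higher number a weaker inhibitor. Compound 1 `CCCCc1c(F)c(N)c2c(=O)cc(-c3ccc(N)c(F)c3)oc2c1F` gives > 100000 nM in this assay, and that figure is a limit of the assay rather than a number (the limit of > 100000 nM in this assay, at which 1 of the 3 values shown sits). Compound 2 `Nc1ccc(-c2cc(=O)c3c(N)c(F)c(CO)c(F)c3o2)cc1F` gives 24000 nM in this assay, and compound 3 `CN(C)CCCC(=O)OCc1c(F)c(N)c2c(=O)cc(-c3ccc(N)c(F)c3)oc2c1F` gives 4500 nM. Compound 3 therefore stands at the lowest of the two numbers available, with compound 2 nearest; the step of a 5.3-fold lower number from compound 2 to compound 3 (0.73 log units; beyond the scatter) separates them, and the step of an at least 22-fold lower number from compound 1 to compound 3 (1.34 log units; beyond the scatter) is the largest in the set, while an at least 4.1-fold lower number from compound 1 to compound 2 (0.61 log units; beyond the scatter) is smaller.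

Compound 4 `COCc1c(F)c(N)c2c(=O)cc(-c3ccc(N)c(F)c3)oc2c1F` differs from compound 3 in one place: methyl in place of (3-(dimethylamino)propyl)carbonyl on an oxygen on a saturated carbon. The step that bears most directly on this change is a 5.3-fold lower number from compound 2 to compound 3 (0.73 log units; beyond the scatter). It concerns the same oxygen on the same saturated carbon. Compound 4 keeps neither the hydroxy of compound 2 nor the ester of compound 3, and with only a methyl in that position the expectation is a modest step back toward the number of compound 2, that is a 4.4-fold higher number from compound 3 to compound 4 (0.65 log units; beyond the scatter) toward a higher number in this assay. Compound 4 is accordingly estimated at 20000 nM in this assay, with a range from 6000 nM to 60000 nM.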

Compound 4, half-maximal inhibitory concentration: > 100000 nM
Compound 4 was reported as a limit; the forecaster's own chance of this, stated with the estimate: 10%; middle value at least 5.0-fold (0.69 log units) from the limit.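

Read on the oxygen on the saturated carbon in this assay, the change shows that replacing the hydrogen of compound 2 with even a single methyl moves the number up, an at least 4.1-fold higher number from compound 2 to compound 4 (0.61 log units; beyond the scatter), so this oxygen does not tolerate every substituent. Replacing the (3-(dimethylamino)propyl)carbonyl with methyl gives an at least 22-fold higher number from compound 3 to compound 4 (1.34 log units; beyond the scatter), which shows that the lower number of compound 3 does not come from simply capping the oxygen; among these three compounds the order is ester, then hydroxy, then methyl ether. Compound 4 is a limit of the assay rather than a number, as is compound 1, so the step between those two cannot be read: the limit of > 100000 nM in this assay, at which 2 of the 4 values shown sit.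

The compounds shown do not separate the part played by the carbonyl from that of the terminal dimethylamino group, since the ester and the amine enter and leave together. A plain acetyl ester, which has the carbonyl without the amine, and an ether bearing the 3-(dimethylamino)propyl chain, which has the amine without the carbonyl, would pull the two apart.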